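Heteroaryl swap on the shared core: compound 2 to compound 4

The source may hold more compounds than are shown below. What is called first, only, known or untested is meant among the compounds shown, and "the series" means these compounds.

Measured so far:
compound 1 `O=C1NC(O)(/C=C\n2cc(I)c3c(Cl)ncnc32)C(OCc2ccccc2)=C1OCc1ccccc1`: in a functional assay on MIA PaCa-2 cells (Homo sapiens) for antiproliferative activity, read by MTT assay, with a stated time of 72 h (on this read-out lower numbers stand for stronger inhibition and higher numbers for weaker inhibition), compound 1 gives 22600 nM
compound 2 `O=C1O/C(=C\Cn2cnc3c(Cl)c(F)nc(F)c32)C(OCc2ccccc2)=C1OCc1ccccc1`: in this assay compound 2 gives only a limit, > 100000 nM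
compound 3 `O=C1O/C(=C\Cn2cnc3ccn(C/C=C4\OC(=O)C(OCc5ccccc5)=C4OCc4ccccc4)c3c2=O)C(OCc2ccccc2)=C1OCc1ccccc1`: in this assay compound 3 gives 26200 nM

Compound 2 stands at the limit of this assay, so no number is known for it; see (the limit of > 100000 nM in this assay, at which 1 of the 3 values shown sits). Compound 1 and compound 3 lie within the usual scatter of each other. Compound 4 `O=C1O/C(=C\Cn2cnc3ccnc(Cl)c32)C(OCc2ccccc2)=C1OCc1ccccc1` differs from compound 2 by a group of 10 heavy atoms (6 carbon, 3 nitrogen, 1 chlorine; one five-membered aromatic ring with 2 hetero atoms, one six-membered aromatic ring with 1 hetero atom) in place of a group of 12 heavy atoms (6 carbon, 3 nitrogen, 2 fluorine, 1 chlorine; one five-membered aromatic ring with 2 hetero atoms, one six-membered aromatic ring with 1 hetero atom), on a saturated chain carbon bound to a double-bonded chain carbon. Among the compounds with values here, no measured step covers this change. In this assay a measurable number is expected for compound 4, near the range of compound 1 at 22600 nM. Compound 4 is expected at 40000 nM, between 15000 nM and 100000 nM. The estimated step, an at least 2.5-fold lower number from compound 2 to compound 4 (0.39 log units; beyond the scatter), starts from a limit and is therefore uncertain in size.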

Compound 4, half-maximal inhibitory concentration: > 100000 nM
Compound 4 was reported as a limit; the forecaster's own chance of this, stated with the estimate: 35%; middle value at least 2.5-fold (0.39 log units) away from the limit.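

Compound 2 and compound 4 are both reported only as limits, so no step can be read between them: the limit of > 100000 nM in this assay, at which 2 of the 4 values shown sit.
As far as these compounds go, whether the 10-heavy-atom group changes activity on the shared core relative to the 12-heavy-atom group stays open.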